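The source may report more compounds than this note shows. Statements on the series, on what has been measured and on what is new or still open speak of the compounds shown alone.

Compound 1 `COc1ccc(S(=O)(=O)Oc2ccccc2/C=C(\C#N)C(=O)Nc2nnc(Cc3cccc4ccccc34)s2)cc1` gives 98% in a functional assay on HL-60 cells (Homo sapiens) for inhibition, read by CCK-8 assay, with a stated time of 48 h, tested at 20 uM; on this read-out lower numbers stand for less inhibition of growth and higher numbers for more inhibition of growth at the one concentration tested. Compound 2 `N#C/C(=C\c1ccccc1OS(=O)(=O)c1ccc([N+](=O)[O-])cc1)C(=O)Nc1nnc(Cc2cccc3ccccc23)s1` differs from it by nitro in place of methoxy on an aromatic carbon, and in this assay compound 2 gives 18%, a step of a number 80 percentage points lower from compound 1 to compound 2 (beyond the scatter). Compound 3 `COc1ccc(S(=O)(=O)Oc2ccccc2/C=C(\C#N)C(=O)Nc2nnc(Cc3ccccc3)s2)cc1` has a different core, the difference being (phenyl in place of naphthalen-1-yl on a saturated chain carbon bound to an aromatic carbon), and in this assay compound 3 gives 100%, which is a number 2 percentage points higher from compound 1 to compound 3 (within the scatter). For the measured compounds named here, compound 4 `N#C/C(=C\c1ccccc1OS(=O)(=O)c1ccc([N+](=O)[O-])cc1)C(=O)Nc1nnc(Cc2ccccc2)s1` is not yet measured; it differs from compound 3 by nitro in place of methoxy on an aromatic carbon, the same change as the one between compound 1 and compound 2. Given that the earlier step, a number 80 percentage points lower from compound 1 to compound 2 (beyond the scatter), was beyond the scatter, a step of similar size is expected here, estimated as a number 80 percentage points lower from compound 3 to compound 4 (beyond the scatter). Compound 4 is therefore estimated at 20% in this assay, between 5% and 45%.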

Compound 4, percent growth inhibition at one concentration: 20%
Compound 4: middle estimate and measured number agree at the digits printed, and the stated range covers the measured number.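

In this assay, for the compounds shown here, nitro in place of methoxy gives a number 80 percentage points lower from compound 3 to compound 4 (beyond the scatter), and the change carries over between the two cores without loss of size: the same change on two cores in this assay, a number 80 percentage points lower (beyond the scatter) from compound 1 to compound 2 and a number 80 percentage points lower (beyond the scatter) from compound 3 to compound 4, 0 percentage points apart, within the scatter of two such steps Phenyl in place of naphthalen-1-yl gives a number 2 percentage points higher from compound 2 to compound 4 (within the scatter), which matches the earlier step: the same change on two cores in this assay, a number 2 percentage points higher (within the scatter) from compound 1 to compound 3 and a number 2 percentage points higher (within the scatter) from compound 2 to compound 4, 0 percentage points apart, within the scatter of two such steps This holds for only two cores at one concentration, so it shows that the changes carried over here, not that they would on any other core, and it does not explain the drop with nitro.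

From the compounds shown here alone, it remains open whether an amine or a carboxylic acid in place of the methoxy would read like compound 3 or like compound 4. Going by these compounds, it is also open how a longer chain in place of the phenyl would behave.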